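A few compounds are considered here, and "the series" means these few. Any claim that something is new, unique, unknown or untested is made for them only; others in the source may bear on it.

Working notes on the series. Among the compounds with values here, all measured members share one core; compound 1 `Cc1nnc(Sc2cc(NC(=O)c3ccc(Cl)cc3)c3ccccc3c2O)s1` is the first. In a functional assay on HCT-116 cells (Homo sapiens) for antiproliferative activity, read by MTT assay, with a stated time of 48 h (on this read-out lower numbers stand for stronger inhibition and higher numbers for weaker inhibition), compound 1 gives only a limit, > 100000 nM. Compound 2 `O=C(Nc1cc(Sc2ncn[nH]2)c(O)c2ccccc12)c1cccc(Cl)c1` in this assay also gives only a limit, > 100000 nM. Compound 3 `O=C(Nc1cc(Sc2nncs2)c(O)c2ccccc12)c1ccc(Cl)cc1` in this assay likewise gives only a limit, > 100000 nM. Compound 3 therefore stands where the whole measured set stands, at the limit, with no number to set it apart from compound 1 or compound 2. Because the limit of > 100000 nM in this assay, at which 3 of the 3 values shown sit, holds every shown value at the limit, the single one-place step that the two limits leave unreadable from compound 1 to compound 3 cannot be sized.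

Compound 4 `Cn1nnnc1Sc1cc(NC(=O)c2ccc(Cl)cc2)c2ccccc2c1O` is the next member; its difference from compound 3 is 1-methyl-1H-tetrazol-5-yl in place of 1,3,4-thiadiazol-2-yl on a sulfur. Within the data shown here, no measured step bears directly on this exchange, and the only step available, a step that the two limits leave unreadable from compound 1 to compound 3, is unreadable. With the whole series at the limit, compound 4 is expected to remain there, the step that the limit leaves unreadable from compound 3 to compound 4 not beyond the scatter. Compound 4 is thus estimated at 150000 nM, within 50000 nM to 500000 nM.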

Compound 4, half-maximal inhibitory concentration: > 100000 nM
Compound 4: a limit, no number; the forecaster's own chance of this, stated with the estimate: 85%; the middle value lies beyond the limit too.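

In this assay compound 4 gives > 100000 nM, a limit and not a number. The steps to compound 4 from compound 3 and from compound 1 therefore cannot be read: the limit of > 100000 nM in this assay, at which 4 of the 4 values shown sit.

The compounds shown leave open whether any exchange of the group on the sulfur changes the read-out at all.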